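Swapping the Aryl Group on the Ring Amine Nitrogen

A few compounds are considered here, and "the series" means these few. Any claim that something is new, unique, unknown or untested is made for them only; others in the source may bear on it.

Compound 1 `Cc1nc(-c2cccc(F)c2)c(C(=O)N2CCN(c3cccc(Cl)c3)CC2)o1`: 33.7 nM
Compound 2 `Cc1nc(-c2ccccc2)c(C(=O)N2CCN(c3cccc(C)c3C)CC2)o1`: 35 nM
Compound 3 `CCc1nc(-c2ccc(C(C)C)cc2)c(C(=O)N2CCN(c3cccc(OC)c3)CC2)o1`: 887 nM

All three numbers come from a functional assay on HL-60 cells (Homo sapiens) for inhibition, read by MTT assay, with a stated time of 72 h; a lower number here means a stronger inhibitor, a higher number a weaker inhibitor. Compound 2 stands second highest of the three. Its nearest neighbour is compound 1, whose number lies within the scatter of repeated measurements; its furthest is compound 3, whose far higher number lies beyond the scatter. Compound 4 `Cc1nc(-c2ccccc2)c(C(=O)N2CCN(c3ccccc3C(F)(F)F)CC2)o1` is not yet measured in this assay. It differs from compound 2 at one place: 2-(trifluoromethyl)phenyl in place of 2,3-dimethylphenyl on an amine nitrogen in a ring. Among the measured compounds shown here, no measured pair differs in a single place, so nothing in the numbers shows how large such a change is. Compound 4 is expected to stay near compound 2, with a step of a 1.4-fold higher number from compound 2 to compound 4 (0.15 log units; within the scatter) that should not exceed the scatter. Compound 4 is therefore estimated at 50 nM, in the range 15 nM to 250 nM.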

Compound 4, half-maximal inhibitory concentration: 120 nM
Compound 4: middle estimate off by 2.4-fold (0.38 log units), on the low side, within the range that was stated.
By their numbers in this assay, from the lowest: compounds 1 and 2 (each within the scatter of the next); then compound 4; then compound 3.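

In this assay, among the compounds shown here, this is the first change made at a single place, and swapping 2,3-dimethylphenyl for 2-(trifluoromethyl)phenyl on the ring amine nitrogen gives a 3.4-fold higher number from compound 2 to compound 4 (0.54 log units; beyond the scatter) as a modest but real loss of inhibition. The earlier compounds shown here differed in several places at once, so they could not show that this aryl group alone moves the number. Nothing at hand explains the step.

On these data alone, whether the loss follows from the trifluoromethyl group itself or from the absent methyl groups stays open. So does the outcome with a plain phenyl, or with a nitrile or carboxylic acid on this aryl ring.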